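Chain-end variation in a pyridyl alkenoic acid series

This account rests on a few compounds, and the source may have more. Where it says the series, first, only, none or still open, it means among the compounds named here.

Measured so far:
compound 1, `CSC(CCC/C=C(\c1ccccc1)c1cccnc1)C(=O)O`: 30 nM
compound 2, `O=C(O)CCCC/C=C(\c1cccnc1)c1cccc(F)c1`: 55 nM
compound 3, `O=C(O)CCCCCC(c1ccccc1)c1cccnc1`: 2700 nM

In an assay (Equus caballus) for inhibition of Thromboxane-A synthase (Homo sapiens), using microsomes (on this read-out lower numbers stand for stronger inhibition and higher numbers for weaker inhibition), compound 1 gives the lowest of the three numbers. Compound 2 sits close to it, and the two values lie within the scatter of each other, so no order between compound 1 and compound 2 is claimed. Compound 3, which has a saturated chain where compound 1 and compound 2 carry a double bond, gives a number far higher than compound 1, and that gap lies beyond the scatter. For the measured compounds named here, only the values themselves are known for these pairs; no single-point step between measured compounds is available.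

Compound 4, `CC(C)(CCCC/C=C(\c1ccccc1)c1cccnc1)C(=O)O`, is not yet measured. It differs from compound 1 as follows: 2-carboxy-2-methylpropyl in place of carboxy(methylsulfanyl)methyl on a saturated chain carbon, three bonds along the chain from a double-bonded chain carbon. The double bond and both aromatic rings of compound 1 are kept; the change is confined to the chain end carrying the carboxylic acid.

With no measured step of this kind in the series, the expectation for compound 4 rests on the retained features shared with compound 1 and compound 2. The step of a 2.0-fold higher number from compound 1 to compound 4 (0.30 log units; within the scatter) is expected to be small, at most a modest weakening, and may fall within the scatter. Compound 4 is estimated at 60 nM, with a range from 15 nM to 250 nM in this assay.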

Compound 4, half-maximal inhibitory concentration: 45 nM
Compound 4: middle estimate off by 1.3-fold (0.12 log units), on the high side; measured number inside the range.
By their numbers in this assay, from the lowest: compounds 1, 4 and 2 (each within the scatter of the next); then compound 3.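

In this assay, for the compounds shown here, putting 2-carboxy-2-methylpropyl in place of carboxy(methylsulfanyl)methyl on a saturated chain carbon, three bonds along the chain from a double-bonded chain carbon, gives a 1.5-fold higher number from compound 1 to compound 4 (0.18 log units; within the scatter), the first step that can be read at a single place. This chain end therefore accepts a substantial rewrite, with the sulfur atom gone and the carbon count of the group raised, and the two numbers cannot be told apart in this assay. No measurement at hand bears on what lies behind so small a step.

The step alters several features of the chain end at once, so the loss of the methylsulfanyl group, the gain of the two methyl groups and the shifted place of the carboxylic acid are not separated from one another. Whether this position needs a carboxylic acid at all stays open, since every compound shown carries one, and a tetrazole or a primary amide at the chain end would address that question.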